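This account rests on a few compounds, and the source may have more. Where it says the series, first, only, none or still open, it means among the compounds named here.

Compound 1 `CC(C)(C)Cc1c(-c2ccc(Cl)cc2)sc(N)c1C(=O)c1ccc(Cl)cc1` stands at the bottom of the range measured: in an assay on CHO cells for displacement of a labelled ligand from adenosine receptor A3 (Homo sapiens), read by scintillation counting, tested at 10 uM (on this read-out higher numbers stand for more inhibition at the one concentration tested (going by the name of the read-out) and lower numbers for less inhibition), compound 1 gives 1%, level with compound 2. Compound 2 `CC(C)(C)Cc1c(-c2ccc(OC(F)(F)F)cc2)sc(N)c1C(=O)c1ccc(Cl)cc1` gives 1% in this assay, and the step of no change at the digits printed from compound 1 to compound 2 (within the scatter) shows that swapping one group on the aryl ring left the read-out untouched. Compound 3 `Cc1noc(C)c1-c1sc(N)c(C(=O)c2ccc(Cl)cc2)c1CC(C)(C)C` differs from compound 1 by 3,5-dimethyl-1,2-oxazol-4-yl in place of 4-chlorophenyl on an aromatic carbon. Going by the values given here, the single measured step offers no sign of movement, so no change beyond the scatter is expected here either. Compound 3 is therefore expected to give 3%, between -8% and 15%. That estimate means a step of a number 2 percentage points higher from compound 1 to compound 3 (within the scatter), expected to stay within the scatter.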

Compound 3, a percentage reported as inhibition, at one concentration (the size of the read-out at that concentration, not a potency): 1%
Compound 3: middle estimate off by 2 percentage points, on the high side, and the stated range covers the measured number.
By their numbers in this assay, from the lowest: compounds 1, 2 and 3 (each within the scatter of the next).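

Until now only a group on the aryl ring had changed. Here the whole 4-chlorophenyl gives way to 3,5-dimethyl-1,2-oxazol-4-yl, and this assay shows no change at the digits printed from compound 1 to compound 3 (within the scatter) even though the entering ring is five-membered and carries 2 hydrogen-bond acceptors. At this carbon, then, neither a different ring nor added acceptors moved the read-out, and nothing available explains this result. Still open, as far as these compounds go, is whether a carboxylic acid or an amine such as piperidine on this carbon would raise the inhibition, or whether a shorter chain in place of neopentyl would.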